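Swapping fluoro for cyano on a cytotoxicity series

This account rests on a few compounds, and the source may have more. Where it says the series, first, only, none or still open, it means among the compounds named here.

For the measured compounds named here, compound 1 `Cc1nnc(SCC(=O)N/N=c2/scc(-c3ccc(F)cc3)n2-c2ccccc2)s1` was tested in an ADME assay on NIH3T3 cells (Mus musculus) for cytotoxicity, read by MTT assay, with a stated time of 24 h (a lower number here means a stronger inhibitor, a higher number a weaker inhibitor), where compound 1 gives 383 ug/mL, the highest of the two numbers so far. Going by the values given here, its only measured neighbour, compound 2 `Cn1cnnc1SCC(=O)N/N=c1/scc(-c2ccc(F)cc2)n1-c1ccccc1`, gives 65 ug/mL in this assay, a change of a 5.9-fold lower number from compound 1 to compound 2 (0.77 log units; beyond the scatter). Compound 3 `Cc1nnc(SCC(=O)N/N=c2/scc(-c3ccc(C#N)cc3)n2-c2ccccc2)s1` differs from compound 1 by cyano in place of fluoro on an aromatic carbon. Among the compounds with values here, the one measured step alters a different part of the molecule, so no measured step speaks directly to this change. With nothing to point either way, compound 3 is expected to sit close to compound 1, a step of a 1.1-fold lower number from compound 1 to compound 3 (0.04 log units; within the scatter), giving an estimated 350 ug/mL with a range of 150 ug/mL to 800 ug/mL.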

Compound 3, half-maximal inhibitory concentration: < 3.9 ug/mL
Compound 3 ended at the assay's limit; the forecaster's own chance of this, stated with the estimate: 10%; at least 89-fold (1.95 log units) between middle value and limit.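

Replacing 4-fluorophenyl with 4-cyanophenyl shows that this end of the molecule, which the earlier step left untouched, can strongly change the result in this assay, with an at least 98-fold lower number from compound 1 to compound 3 (1.99 log units; beyond the scatter). Compound 3 gives < 3.9 ug/mL, which is a limit of the assay and not a number: the limit of < 3.9 ug/mL in this assay, at which 1 of the 3 values shown sits.

Going by these compounds, whether other groups at this position, such as an amine or a carboxylic acid, would shift the number as far remains open. It is also unknown whether the same swap would act alike on compound 2, with its 4-methyl-4H-1,2,4-triazol-3-yl group.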